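The compounds below may be only part of what the source reports. "The series", "measured", "known", "first", "only" and "open" are said of these compounds alone.

Among the measured compounds shown here, compound 1 `Cc1ccc(OCCCCOc2ccc(C(=O)CC(C)(C)C)c(O)c2C)cc1C(=O)O` is one of two compounds measured in an assay for positive allosteric modulation of metabotropic glutamate receptor 2 (Rattus norvegicus) (a higher number here means that more compound is needed for the effect, a lower number that less compound is needed), where compound 1 gives 210 nM; this is the highest of the two numbers. Its nearest neighbour is compound 2 `Cc1c(OCCCCOc2ccc(C(=O)O)cc2F)ccc(C(=O)CC(C)(C)C)c1O`, which in this assay gives 75 nM, a change described by a 2.8-fold lower number from compound 1 to compound 2 (0.45 log units; beyond the scatter). Compound 3 `Cc1c(OCCCCOc2ccc(F)c(C(N)=O)c2)ccc(C(=O)CC(C)(C)C)c1O` has not yet been measured. It differs from compound 1 by 3-carbamoyl-4-fluorophenyl in place of 3-carboxy-4-methylphenyl on an oxygen on a saturated carbon. For the measured compounds named here, only the step from compound 1 to compound 2 bears on this change, and only in part: it also brings a fluorine onto the aryl ring but keeps the carboxylic acid, whereas compound 3 exchanges the acid for an amide, a change for which no measured pair exists. The step of a 2.8-fold lower number from compound 1 to compound 2 (0.45 log units; beyond the scatter) was modest. With the acid gone, compound 3 is expected to need somewhat more compound than compound 1, an estimated step of a 1.4-fold higher number from compound 1 to compound 3 (0.15 log units; within the scatter). Compound 3 is therefore estimated at 300 nM, with a range from 90 nM to 1000 nM.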

Compound 3, half-maximal effective concentration: > 10000 nM
Compound 3: a limit, no number (the forecaster's own chance of this, stated with the estimate: 10%); middle value at least 33-fold (1.52 log units) from the limit.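

Compound 3 stands at a limit of this assay, not at a number: the limit of > 10000 nM in this assay, at which 1 of the 3 values shown sits. Placing 3-carbamoyl-4-fluorophenyl on this oxygen on a saturated carbon gives an at least 47-fold higher number from compound 1 to compound 3 (1.67 log units; beyond the scatter) and an at least 130-fold higher number from compound 2 to compound 3 (2.12 log units; beyond the scatter), both large steps. The earlier compounds shown here showed this position only with a carboxylic acid on the aryl ring, where the change between them was modest; compound 3 shows that this position does not accept every aryl group of the same size, since the groups that leave and enter count the same number of heavy atoms.

The compounds shown leave open how much of this step belongs to the carbamoyl group and how much to the fluorine, which a 3-carboxy-4-fluorophenyl group would separate. They also leave open how a tetrazole or a methyl ester would fare in place of the carboxylic acid.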